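A few compounds are considered here, and "the series" means these few. Any claim that something is new, unique, unknown or untested is made for them only; others in the source may bear on it.

In an ADME assay on L1210 cells (Mus musculus) for cytotoxicity, with a stated time of 48 h (a higher number here means a weaker inhibitor, a lower number a stronger inhibitor), compound 1 (`CC1=CCC[C@](C)(CC/C(C)=C/CC2=C(O)C(=O)C=C(N[C@@H](C(=O)O)[C@@H](C)O)C2=O)[C@@H]1C`) gives > 10 ug/mL as a limit of the assay. Compound 2 (`C=C1[C@H](C)CCC[C@]1(C)CC/C(C)=C/CC1=C(O)C(=O)C=C(N[C@H](C(=O)O)[C@@H](C)O)C1=O`) gives > 10 ug/mL as a limit too. Compound 3 (`C=C1[C@H](C)CCC[C@]1(C)CC/C(C)=C/CC1=C(O)C(=O)C=C(N[C@@H](C(=O)O)[C@@H](C)O)C1=O`) stands at > 10 ug/mL as well, again a limit and not a number. Compound 4 (`C=C1[C@H](C)CCC[C@]1(C)CC/C(C)=C/CC1=C(O)C(=O)C=C(N[C@H](C(=O)O)[C@H](C)O)C1=O`) relates to compound 3 as follows: the two compounds have the same atoms and bonds and differ only in configuration as drawn: 2 of 5 stereo elements differ; a stereocentre at a saturated chain carbon is drawn R in compound 3 and S in compound 4; a stereocentre at a saturated chain carbon is drawn R in compound 3 and S in compound 4 in all. The closest evidence is a step that the two limits leave unreadable from compound 2 to compound 3 for a change of configuration alone, while a step that the two limits leave unreadable from compound 1 to compound 3 concerns the ring group. Neither gives a size, so no direction can be drawn from them, and no step beyond the scatter is expected on the strength of the limit of > 10 ug/mL in this assay, at which 3 of the 3 values shown sit, alone. The expected change is a step that the limit leaves unreadable from compound 3 to compound 4 at most a nominal one. Compound 4 is estimated at 15 ug/mL with a range from 6 ug/mL to 40 ug/mL and will probably be reported only as a limit.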

Compound 4, half-maximal inhibitory concentration: > 10 ug/mL
Compound 4: only a limit was reported; the forecaster's own chance of this, stated with the estimate: 80%; the middle value does not contradict the limit.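

Among the compounds shown here, compound 4 is reported only as a limit, as are compound 2 and compound 3, so no step to compound 4 from either can be read. The compounds shown leave open whether configuration affects the read-out in this assay at all.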